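This account rests on a few compounds, and the source may have more. Where it says the series, first, only, none or still open, it means among the compounds named here.

Of the compounds shown here, three built on one shared core have been measured, and a fourth has not. Compound 1 `O=c1ccc(-c2ccc3cn[nH]c3c2)cn1Cc1ccccc1C(F)(F)F` gives 133 nM in an assay for inhibition of MAP kinase-interacting serine/threonine-protein kinase 1 (Homo sapiens), read by luminescence and ADP-Glo, with a stated time of 2 h; on this read-out higher numbers stand for weaker inhibition and lower numbers for stronger inhibition. Compound 2 `Cn1ncc2ccc(-c3ccc(=O)n(Cc4ccccc4)c3)cc21` gives > 2000 nM in this assay, which is a limit of the assay rather than a number. Compound 3 `O=C(N1CCOCC1)n1cc(-c2ccc3cn[nH]c3c2)ccc1=O` likewise gives > 2000 nM in this assay, again a limit and not a number. Compound 3 therefore stands at the weak end of what has been seen: it sits at the limit of > 2000 nM in this assay, at which 2 of the 3 values shown sit, so all that is known is that it inhibits more weakly than the assay can resolve, with compound 1 the only one of the three that yields an actual number.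

Compound 4 `O=c1ccc(-c2ccc3cn[nH]c3c2)cn1Cc1cccc(Cl)c1` arises from compound 3 by a single change: 3-chlorobenzyl in place of (morpholin-4-yl)carbonyl on an aromatic nitrogen. Compound 2 also carries a benzyl on that nitrogen but differs from compound 1 in more than one place, so its limit cannot be tied to the benzyl alone. With compound 1 showing 133 nM for a substituted benzyl on the same nitrogen, the step from compound 3 to compound 4 is expected to be a large gain in inhibition, an at least 10-fold lower number from compound 3 to compound 4 (1.00 log units; beyond the scatter). Compound 4 is estimated at 200 nM, in a range from 60 nM to 1000 nM.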

Compound 4, half-maximal inhibitory concentration: 37 nM
Compound 4: middle estimate off by 5.4-fold (0.73 log units), on the high side; measured number below the stated range.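

Among the compounds shown here, putting 3-chlorobenzyl in place of (morpholin-4-yl)carbonyl on this aromatic nitrogen gives an at least 54-fold lower number from compound 3 to compound 4 (1.73 log units; beyond the scatter) in this assay, and this pair shows what the earlier compounds could not: with only this one place changed, the group on that nitrogen alone takes inhibition from unreadable to clearly measurable. The two groups have the same count of heavy atoms, so the gap does not follow from that count; what differs is that a carbon-only aromatic ring bearing chlorine replaces a non-aromatic ring with hetero atoms and a carbonyl. The size of this step is a minimum and not an exact figure, because compound 3 gives only a limit of the assay: the limit of > 2000 nM in this assay, at which 2 of the 4 values shown sit.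

From the compounds shown here alone, it remains open how much of the gain belongs to the benzyl frame and how much to the chlorine, a question that a plain benzyl on the same core would help to settle. Also open, going by these compounds, is whether inhibition would hold with a methoxy on that ring, with a longer chain such as phenethyl, or with an amine on the same nitrogen.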